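A few compounds are considered here, and "the series" means these few. Any claim that something is new, unique, unknown or untested is made for them only; others in the source may bear on it.

Measured so far in an ADME assay on L929 cells (Mus musculus) for cytotoxicity, read by resazurin assay, with a stated time of 96 h; a higher number here means that more compound is tolerated, a lower number that less compound is tolerated:
- Compound 1 `CCc1ccc(OC/C(=N\NC(N)=S)c2ccc(Br)cc2)cc1`: < 25500 nM (a limit)
- Compound 2 `NC(=S)N/N=C(\COc1ccc(F)c(Cl)c1)c1ccc(Br)cc1`: 48000 nM
- Compound 3 `NC(=S)N/N=C(\COc1ccc(Cl)c(Cl)c1)c1ccc(Br)cc1`: 23100 nM

Compound 1 has no exact number in this assay, only the limit < 25500 nM. Its standing on the scale is thus (the limit of < 25500 nM in this assay, at which 1 of the 3 values shown sits).

The next compound to be measured is compound 4 `NC(=S)N/N=C(\COc1ccc(-c2ccccc2)cc1)c1ccc(Br)cc1`, which differs from compound 1 in a single exchange: phenyl in place of ethyl on an aromatic carbon. Phenyl takes the place of ethyl on an aromatic carbon, para to a large group.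

Going by the values given here, only one measured step is available for comparison, a 2.1-fold lower number from compound 2 to compound 3 (0.32 log units; beyond the scatter), a modest change with chloro in place of fluoro on an aromatic carbon. That step involves a different exchange, so it bears on this one only loosely. Among the compounds with values here, no measured pair shows ethyl giving way to phenyl, and the starting point is not an exact number. A modest step toward a lower number in this assay is therefore expected, but with little confidence in its direction. The estimated step is a step that the limit leaves unreadable from compound 1 to compound 4, counted from a limit and so only approximate.

For compound 4 the estimated value is 17000 nM, with an expected range from 6000 nM to 45000 nM.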

Compound 4, half-maximal cytotoxic concentration: 90800 nM
Compound 4: middle estimate off by 5.3-fold (0.73 log units), on the low side; measured number above the stated range.
By their numbers in this assay, from the lowest: compound 3; then compounds 2 and 4 (each within the scatter of the next).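

In this assay, putting phenyl in place of ethyl on an aromatic carbon, para to a large group, gives an at least 3.5-fold higher number from compound 1 to compound 4 (0.55 log units; beyond the scatter), so at this position more compound is tolerated with phenyl than with ethyl. Going by these compounds alone, the only earlier step, a 2.1-fold lower number from compound 2 to compound 3 (0.32 log units; beyond the scatter), came from a different exchange and ran toward a lower number, so the earlier compounds did not show that a change on this ring could move the number upward, or that a group of six heavy atoms in place of two could be accompanied by such a rise. The true size of the step remains unknown because compound 1 has no exact number, and the step is therefore a lower bound: the limit of < 25500 nM in this assay, at which 1 of the 4 values shown sits.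

As far as these compounds go, it remains open whether the rise goes with the aromatic ring of phenyl or simply with the larger group, a question that cyclohexyl or a butyl chain at the same place would help to settle. From the compounds shown here alone, it is also open whether the higher number would hold with an amine or a carboxylic acid on the new phenyl ring.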